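Dropping the bromo from compound 3: what to expect

The source may report more compounds than this note shows. Statements on the series, on what has been measured and on what is new or still open speak of the compounds shown alone.

Three related compounds have been examined in an ADME assay on cells (Macrophage, Mus musculus) for cytotoxicity; on this read-out higher numbers stand for lower toxicity in this test and lower numbers for higher toxicity in this test. Compound 1 `OC[C@H]1O[C@@H](c2cnn3c(O)ncnc23)[C@H](O)[C@@H]1O` reaches only the limit of > 64000 nM in this assay. Compound 2 `Nc1nccn2c([C@@H]3O[C@H](CO)[C@@H](O)[C@H]3O)cnc12` also stops at the limit of > 64000 nM. Within the data shown here, compound 3 `Nc1ncnn2c([C@@H]3O[C@H](CO)[C@@H](O)[C@H]3O)cc(Br)c12` gives 2000 nM, the only actual number among the three, while the limit of > 64000 nM in this assay, at which 2 of the 3 values shown sit, describes where the other two stand. Compound 4 `Nc1ncnn2c([C@@H]3O[C@H](CO)[C@@H](O)[C@H]3O)ccc12` differs from compound 3 by hydrogen in place of bromo on an aromatic carbon. No measured pair isolates this single change, so its effect is not yet shown. The two compounds without bromo stay at the limit, though each differs from compound 3 in more than that one place. A rise in the half-maximal cytotoxic concentration is expected, a 10-fold higher number from compound 3 to compound 4 (1.00 log units; beyond the scatter). Compound 4 is therefore estimated at about 20000 nM, between 4000 nM and 64000 nM, with a real chance that only a limit is recorded.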

Compound 4, half-maximal cytotoxic concentration: < 250 nM
Compound 4: only a limit was reported; the forecaster's own chance of this, stated with the estimate: 40%; middle value at least 80-fold (1.90 log units) away from the limit.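

In this assay, among these compounds, this pair isolates the position for the first time: hydrogen in place of bromo on an aromatic carbon gives an at least 8.0-fold lower number from compound 3 to compound 4 (0.90 log units; beyond the scatter). Bromo at this carbon therefore goes with lower toxicity in this test, which compound 1 and compound 2, each differing from compound 3 in more than one place, could not show. The value of compound 4 is itself a limit, so the step has no upper size: the limit of < 250 nM in this assay, at which 1 of the 4 values shown sits.

The compounds shown leave open whether chloro, methyl or an amine on this carbon would keep the number of compound 3 or fall toward that of compound 4.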